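Arylpiperazine succinimide series: pyrimidinyl replacement in the electroshock model

This account rests on a few compounds, and the source may have more. Where it says the series, first, only, none or still open, it means among the compounds named here.

Measured so far:
compound 1 `COc1cccc(N2CCN(C(=O)CN3C(=O)CC(C)(c4ccccc4)C3=O)CC2)c1` — "not active" (no number reported)
compound 2 `COc1ccccc1N1CCN(C(=O)CN2C(=O)CC(C)(c3ccccc3)C2=O)CC1` — 300 mg/kg

Both measured compounds were tested in a functional assay on the whole organism (strain CD-1) with Mus musculus as the target, in the maximal electroshock model, with a stated time of 2 h; a lower number here means that less compound is needed, a higher number that more compound is needed for the effect. Compound 1 gives "not active" (no number reported), so no number is available for it. Among the compounds with values here, compound 2 gives 300 mg/kg in this assay; this is the only number so far, and compound 2 therefore stands alone as the sole reference point, with nothing to rank it against.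

Compound 3 `CC1(c2ccccc2)CC(=O)N(CC(=O)N2CCN(c3ncccn3)CC2)C1=O` has not yet been measured in this assay. Its structural difference from compound 2 is pyrimidin-2-yl in place of 2-methoxyphenyl on an amine nitrogen in a ring. Within the data shown here, no step between two measured compounds is available to calibrate this change, since compound 1 carries no number.

With one reference value only, the expected step from compound 2 to compound 3 in this assay, no change at the digits printed from compound 2 to compound 3 (within the scatter), is set at none beyond the scatter. The expectation for compound 3 is 300 mg/kg, with a range from 100 mg/kg to 600 mg/kg, resting solely on compound 2 and its 300 mg/kg; the chance that the assay reports only inactivity instead of a number is taken as substantial.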

Compound 3, minimum effective dose: "not active" (no number reported)
The entry for compound 3 holds no number, and the estimate cannot be compared.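

In this assay compound 3 gives "not active" (no number reported) and compound 2 gives 300 mg/kg so no step can be read between compound 2 and compound 3. No supporting data bear on this result. The compounds shown leave open whether pyrimidin-2-yl in place of 2-methoxyphenyl changes the dose needed for the effect.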